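The compounds below may be only part of what the source reports. "The series", "measured", "known", "first", "only" and "open" are said of these compounds alone.

Measured so far in a physicochemical assay for lipophilicity, in phosphate buffer, measured as octanol-water partition, at pH 11.5; a higher number here means a more lipophilic compound, a lower number a more polar compound:
- compound 1 `CCCCC(CC)CNC(=N)NC(=N)Nc1ccc(Cl)cc1`: 4.93
- compound 2 `CCCCNC(=N)NC(=N)Nc1ccc(Cl)cc1`: 3.13

Compound 2 holds the lower of the two numbers, at 3.13. Compound 3 `CNC(=N)NC(=N)Nc1ccc(Cl)cc1` is still to be measured. It differs from compound 2 by hydrogen in place of propyl on a saturated chain carbon bound to an amine nitrogen, which is hydrogen in place of propyl on a saturated chain carbon bound to an amine nitrogen. The same difference can also be read as butyl to methyl.

Going by the values given here, only one measured step bears on this: a number 1.80 log units lower from compound 1 to compound 2 (beyond the scatter). There, hydrogen takes the place of butyl on a saturated chain carbon bound to two saturated chain carbons. The two changes are alike in that a saturated chain gives way to hydrogen, but they occur at different places, and propyl is the shorter chain. A single step is thin support, so the range is kept wide. In this assay, a lower number is expected, by a clear margin but by somewhat less than the measured step. The expected change is a number 1.33 log units lower from compound 2 to compound 3 (beyond the scatter). The estimate for compound 3 is 1.8, with an expected range from 1.3 to 2.3.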

Compound 3, partition coefficient: 1.58
The estimate for compound 3 lay 0.22 log units above the measured number; low and high end bracket the measured number.
By their numbers in this assay, from the lowest: compound 3; then compound 2; then compound 1.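

In this assay, the chain on a saturated chain carbon bound to an amine nitrogen still counts at the short end, with hydrogen in place of propyl giving a number 1.55 log units lower from compound 2 to compound 3 (beyond the scatter). Going by these compounds alone, the full change at this place, hydrogen in place of 1-ethylpentyl, gives a number 3.35 log units lower from compound 1 to compound 3 (beyond the scatter), and across these three compounds the number falls with each shortening of the chain, with no compound going against that order. No measured information on hand explains the size of these steps.

The compounds shown leave open whether the order depends on chain length alone or also on branching, since a straight chain of the same size as the one in compound 1 would be needed to separate the two. They also leave open how a chain ending in a hydroxyl, an amine or a carboxylic acid would compare with the plain chains at this place, and whether the steps would keep their size at another buffer pH.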